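A few compounds are considered here, and "the series" means these few. Any claim that something is new, unique, unknown or untested is made for them only; others in the source may bear on it.

The measured compounds:

Compound 1, `O=[N+]([O-])c1ccc(CN2CCC(n3cc(CC(OCc4cc(-c5ccc(Br)cc5)no4)c4ccc(Br)cc4)nn3)CC2)cc1`, gives 4000 nM in a functional assay on MCF7 cells (Homo sapiens) for cytotoxicity, with a stated time of 48 h; a higher number here means a weaker inhibitor, a lower number a stronger inhibitor.
Compound 2, `O=[N+]([O-])c1ccc(CN2CCC(n3cc(CC(OCc4cc(-c5ccc(F)cc5)no4)c4ccc(Br)cc4)nn3)CC2)cc1`, gives 7000 nM in this assay.
Compound 3, `O=[N+]([O-])c1ccc(CN2CCC(n3cc(CC(OCc4cc(-c5cccc(Br)c5)no4)c4ccc(Br)cc4)nn3)CC2)cc1`, gives 6000 nM in this assay.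

All three share one core and differ only in a single aromatic ring at its edge. Going from compound 1 to compound 2, the change is fluoro in place of bromo on an aromatic carbon, and it made a 1.8-fold higher number from compound 1 to compound 2 (0.24 log units; within the scatter). Compound 3 differs from compound 1 in how the same atoms are joined, (3-bromophenyl in place of 4-bromophenyl on an aromatic carbon), and that gave a 1.5-fold higher number from compound 1 to compound 3 (0.18 log units; within the scatter). The values of compound 2 and compound 3 lie close together, a 1.2-fold lower number from compound 2 to compound 3 (0.07 log units; within the scatter).

Compound 4, `O=[N+]([O-])c1ccc(CN2CCC(n3cc(CC(OCc4cc(-c5cccc(F)c5)no4)c4ccc(Br)cc4)nn3)CC2)cc1`, has not been measured yet. It differs from compound 3 by fluoro in place of bromo on an aromatic carbon. This is the same kind of change as that from compound 1 to compound 2, but the place is not the same: there the fluorine sat para to a large group, here it sits meta to a large group. On that basis a step like a 1.7-fold higher number from compound 3 to compound 4 (0.22 log units; within the scatter) is expected, resting on the earlier 1.8-fold higher number from compound 1 to compound 2 (0.24 log units; within the scatter). Compound 4 is therefore estimated at 10000 nM, with a likely range from 5000 nM to 20000 nM.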

Compound 4, half-maximal inhibitory concentration: 8000 nM
For compound 4 the middle estimate is 1.3-fold (0.10 log units) above the measured one, and the stated range covers the measured number.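

Fluoro in place of bromo gave a 1.3-fold higher number from compound 3 to compound 4 (0.12 log units; within the scatter), and in this assay this step agrees with the one seen earlier on the other core: the same change on two cores in this assay, a 1.8-fold higher number (0.24 log units; within the scatter) from compound 1 to compound 2 and a 1.3-fold higher number (0.12 log units; within the scatter) from compound 3 to compound 4, 1.3-fold (0.12 log units) apart, within the scatter of two such steps

The other two new steps, a 1.1-fold higher number from compound 2 to compound 4 (0.06 log units; within the scatter) and a 2.0-fold higher number from compound 1 to compound 4 (0.30 log units; within the scatter), also lie within the scatter, so neither the choice of halogen nor its place on the ring clearly separates these four compounds. This shows that the change stays small on both cores, but not that it has a real effect that carries from one core to another, since a step within the scatter cannot be told apart from repeat-to-repeat variation.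

The compounds shown leave open whether a different kind of group on this aromatic ring, such as an amine or a carboxylic acid, would move the number beyond the scatter. They also leave open how the number responds when the nitro group or the bromo group on the shared core is replaced.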